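The compounds below may be only part of what the source reports. "The series", "measured", "known", "first", "only" and "open" are said of these compounds alone.

Working notes on the series.

Three analogues sharing one core have been measured in an assay on isolated protein for inhibition of DNA topoisomerase 1 (Homo sapiens), with a stated time of 30 min, tested at 100 uM; a higher number here means a stronger effect of the compound at the concentration tested, a lower number a weaker effect. Compound 1 `Oc1ccc(-c2cc(-c3ccccc3)cc(-c3ccccc3)n2)cc1` gives 52.9%. Compound 2 `Oc1ccc(-c2cc(-c3ccccc3)cc(-c3cccs3)n2)cc1` gives 4.9%. Compound 3 `Oc1ccc(-c2cc(-c3ccccc3)cc(-c3ccco3)n2)cc1` gives 18.6%, which places it second highest of the three: the nearest neighbour is compound 2, the furthest is compound 1. The steps recorded so far are a number 48 percentage points lower from compound 1 to compound 2 (beyond the scatter), a number 34.3 percentage points lower from compound 1 to compound 3 (beyond the scatter) and a number 13.7 percentage points higher from compound 2 to compound 3 (beyond the scatter), so both five-membered rings in this position fall well short of the phenyl of compound 1.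

The next compound, compound 4 `Oc1ccc(-c2cc(-c3ccccc3)cc(-c3cccnc3)n2)cc1`, differs from compound 3 as follows: pyridin-3-yl in place of furan-2-yl on an aromatic carbon. For the measured compounds named here, no measured step introduces a six-membered ring with a ring nitrogen, so the bearing steps are indirect; the closest guide is the large step of a number 34.3 percentage points lower from compound 1 to compound 3 (beyond the scatter), read in reverse, since compound 4 returns to a six-membered aromatic ring. Because compound 1 with phenyl gives 52.9% while compound 3 gives 18.6%, the expected step of a number 16.4 percentage points higher from compound 3 to compound 4 (beyond the scatter) is upward, though with wide uncertainty. The estimate for compound 4 in this assay is 35%, expected to fall between 10% and 60%.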

Compound 4, a percentage reported as inhibition, at one concentration (the size of the read-out at that concentration, not a potency): 44%
Estimate against measurement, compound 4: 9 percentage points below; measured number inside the range.
By their numbers in this assay, from the lowest: compound 2; then compound 3; then compounds 4 and 1 (each within the scatter of the next).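

In this assay a ring nitrogen in the six-membered aromatic ring at this position leaves the read-out unresolved from phenyl, with a number 8.9 percentage points lower from compound 1 to compound 4 (within the scatter) as the step. Against the five-membered rings the picture differs, with a number 25.4 percentage points higher from compound 3 to compound 4 (beyond the scatter) and a number 39.1 percentage points higher from compound 2 to compound 4 (beyond the scatter) as the steps, so among these compounds the split runs between the six-membered rings of compounds 1 and 4 and the five-membered rings of compounds 2 and 3, not between rings with and without a hetero atom. Nothing on hand gives a reason for this split.

Open, on these data alone, is how pyridin-2-yl or pyridin-4-yl would read here, and whether an amine or a carboxylic acid on this ring would hold the number. As far as these compounds go, the 4-hydroxyphenyl group stays the same throughout, so what it contributes also remains open.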